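Benzyl-for-Aryl Swap Repeated on a Rearranged Core

The source may hold more compounds than are shown below. What is called first, only, known or untested is meant among the compounds shown, and "the series" means these compounds.

In a functional assay on Ehrlich cells (Mus musculus) for cytotoxicity, read by MTT assay, with a stated time of 24 h (a higher number here means a weaker inhibitor, a lower number a stronger inhibitor), compound 1 `Cn1nc(-c2nnc(SCc3ccc(C(F)(F)F)cc3)o2)cc1-c1ccc(C(F)(F)F)cc1` gives 20500 nM.
In this assay compound 2 `Cn1nc(-c2nnc(SCCc3ccc(F)cc3)o2)cc1-c1ccc(C(F)(F)F)cc1` gives 29200 nM.
In this assay compound 3 `Cn1nc(-c2ccc(C(F)(F)F)cc2)cc1-c1nnc(SCc2ccc(C(F)(F)F)cc2)o1` gives 27300 nM.

Compound 1 and compound 3 contain the same atoms joined differently; the difference between the two cores is not broken down here. Compound 2 comes from compound 1 through one change, (4-fluorobenzyl in place of 4-(trifluoromethyl)phenyl on a saturated chain carbon bound to a sulfur), and that change made a 1.4-fold higher number from compound 1 to compound 2 (0.15 log units; within the scatter). Compound 4 `Cn1nc(-c2ccc(C(F)(F)F)cc2)cc1-c1nnc(SCCc2ccc(F)cc2)o1` comes from compound 3 through the same change, (4-fluorobenzyl in place of 4-(trifluoromethyl)phenyl on a saturated chain carbon bound to a sulfur), at the same place. The step is expected to be a 1.4-fold higher number from compound 3 to compound 4 (0.14 log units; within the scatter), which rests on compound 1 and compound 2 showing a 1.4-fold higher number from compound 1 to compound 2 (0.15 log units; within the scatter), a step within the scatter. Compound 4 is therefore estimated at 38000 nM in this assay, most likely between 16000 nM and 90000 nM. Among the compounds with values here, with only one earlier example of this change, the estimate carries clear uncertainty.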

Compound 4, half-maximal inhibitory concentration: 39500 nM
Estimate against measurement, compound 4: 1.0-fold (0.02 log units) below, within the range that was stated.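

In this assay, placing 4-fluorobenzyl in place of 4-(trifluoromethyl)phenyl on the rearranged core gave a 1.4-fold higher number from compound 3 to compound 4 (0.16 log units; within the scatter). Set beside the earlier case, the two steps agree: the same change on two cores in this assay, a 1.4-fold higher number (0.15 log units; within the scatter) from compound 1 to compound 2 and a 1.4-fold higher number (0.16 log units; within the scatter) from compound 3 to compound 4, 1.0-fold (0.01 log units) apart, within the scatter of two such steps. The change therefore carried from one core to the other with a step of matching size, but both steps lie within the scatter, so this does not show that the change really moves the number, and two cores cannot speak for the whole series.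

The compounds shown leave open what an amine or a carboxylic acid would do in this place, on a saturated chain carbon bound to a sulfur. They also leave open whether a longer chain there would give a step beyond the scatter.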